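Urea to amide at the carbonyl of compound 3

A few compounds are considered here, and "the series" means these few. Any claim that something is new, unique, unknown or untested is made for them only; others in the source may bear on it.

Measured in a functional assay on PC-3 cells (Homo sapiens) for inhibition, read by sulforhodamine B assay, with a stated time of 48 h, tested at 0.1 uM; on this read-out higher numbers stand for a weaker effect at the one concentration tested and lower numbers for a stronger effect:
- compound 1 `O=C(Nc1cccc(-n2cc(-c3ccncc3)c(-c3cc(O)cc(Cl)c3)n2)c1)Nc1ccc(Cl)c(C(F)(F)F)c1` gives 98%
- compound 2 `O=C(Nc1cccc(-n2cc(-c3ccncc3)c(-c3cc(O)cc(Cl)c3)n2)c1)Nc1ccc(Cl)c(Cl)c1` gives 90%
- compound 3 `COc1cc(Cl)cc(-c2nn(-c3cccc(NC(=O)Nc4ccc(Cl)c(Cl)c4)c3)cc2-c2ccncc2)c1` gives 98%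

On these numbers compound 3 stands level with compound 1 at the digits shown, and its value lies within the scatter of that of compound 2. The two measured steps are both small: a number 8 percentage points lower from compound 1 to compound 2 (within the scatter) and a number 8 percentage points higher from compound 2 to compound 3 (within the scatter), each a swap of a substituent.

Compound 4 `COc1cc(Cl)cc(-c2nn(-c3cccc(NC(=O)c4cccc(C(F)(F)F)c4)c3)cc2-c2ccncc2)c1` is not yet measured. It differs from compound 3 in one place: 3-(trifluoromethyl)phenyl in place of (3,4-dichlorophenyl)amino on a carbonyl carbon. Neither measured step touches this part of the shared core; each step changed only a peripheral group, and no change at the carbonyl has been measured here. Among the measured compounds shown here, compound 4 therefore has no directly comparable step to rest on, and its expected value is taken from the three measured compounds, all of which sit at a weak effect in this assay. Compound 4 is estimated at 93%, with a range from 70% to 105%. This expectation implies a number 5 percentage points lower from compound 3 to compound 4 (within the scatter), a step not beyond the scatter.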

Compound 4, a percentage reported as activity, at one concentration (the size of the read-out at that concentration, not a potency): 52%
Beside the measured number, compound 4's estimate is 41 percentage points above it; measured number below the stated range.
By their numbers in this assay, from the lowest: compound 4; then compounds 2, 1 and 3 (each within the scatter of the next).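

In this assay, putting 3-(trifluoromethyl)phenyl in place of (3,4-dichlorophenyl)amino on the carbonyl carbon turns the urea into an amide and gives a number 46 percentage points lower from compound 3 to compound 4 (beyond the scatter). This shows that the read-out responds to a change at the carbonyl, whereas the two earlier swaps of peripheral substituents stayed within the scatter. Nothing on hand accounts for the size of this step.

The single step changes two things at once, removing the amino nitrogen with its hydrogen-bond donor and exchanging the two chlorines for a trifluoromethyl, so the compounds shown leave open which of these goes with the lower number. Also open, from the compounds shown here alone, is how this position would respond to a sulfonamide in place of the amide, or to a morpholine on the aromatic ring that the carbonyl carries.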